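Allyl for Methoxyethoxymethyl on a Shared Cytotoxic Core

The compounds below may be only part of what the source reports. "The series", "measured", "known", "first", "only" and "open" are said of these compounds alone.

Compound 1 `Cn1cc(C(N)=O)c2c(N)ncnc21`: in a functional assay on KB cells (Homo sapiens) for cytotoxicity (on this read-out higher numbers stand for weaker inhibition and lower numbers for stronger inhibition), compound 1 gives > 100000 nM, which is a limit of the assay rather than a number.
Compound 2 `COCCOCn1cc(C(N)=O)c2c(N)ncnc21`: in this assay compound 2 gives > 100000 nM, again a limit of the assay and not a number.

Within the data shown here, compound 2 therefore stands at the edge of what this assay can report: only a limit is known for it, and the same holds for the one other value shown. Among the measured compounds shown here, the single measured step, a step that the two limits leave unreadable from compound 1 to compound 2, cannot be read in size or direction because the limit of > 100000 nM in this assay, at which 2 of the 2 values shown sit, is where both of its ends sit. For the measured compounds named here, no other step is available.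

Compound 3 `C=CCn1cc(C(N)=O)c2c(N)ncnc21` differs from compound 2 in one place: vinyl in place of 2-methoxyethoxy on a saturated chain carbon bound to an aromatic nitrogen. Going by the values given here, nothing measured shows that a change at this position, on a saturated chain carbon bound to an aromatic nitrogen, moves the read-out in this assay in either direction, and the change from a chain to a shorter one with no acceptors has no measured counterpart here. The expectation is therefore no step beyond the scatter, a number no higher from compound 2 to compound 3 (the limit leaves the size open), with compound 3 most likely remaining at a limit. Compound 3 is estimated at 100000 nM, within a range of 20000 nM to 500000 nM.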

Compound 3, half-maximal inhibitory concentration: 100000 nM
Estimate against measurement, compound 3: no gap at the digits printed, within the range that was stated.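

In this assay, among these compounds, compound 3 gives 100000 nM, a true number rather than a limit and the first number at this position. Among the compounds shown here, both new steps point the same way, a number no higher from compound 2 to compound 3 (the limit leaves the size open) and a number no higher from compound 1 to compound 3 (the limit leaves the size open), so allyl is the first group here that lets the read-out be stated as a number rather than a limit. Neither step can be given a size, and the direction is only partly settled, because both compounds on the other side of these steps rest on a limit: the limit of > 100000 nM in this assay, at which 2 of the 3 values shown sit.

The compounds shown leave open how far compound 1 and compound 2 lie from compound 3, and so whether the change from (2-methoxyethoxy)methyl to allyl matters much or little on this read-out. They also leave open how a longer chain, a benzyl group or a chain ending in an amine would read on a saturated chain carbon bound to an aromatic nitrogen, and only such groups, giving numbers clearly lower than that of compound 3, could show whether this position can move the read-out at all.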